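Bromo in place of methoxy: notes on tolerated concentration

The source may hold more compounds than are shown below. What is called first, only, known or untested is meant among the compounds shown, and "the series" means these compounds.

Measured in an ADME assay on HEK-293T cells (Homo sapiens) for cytotoxicity, read by MTT assay, with a stated time of 24 h; a lower number here means that less compound is tolerated, a higher number that more compound is tolerated
- compound 1 `Cc1ccc(-c2nn(-c3ccccc3)cc2-c2nc3ccccc3n2S(=O)(=O)c2ccc(Br)cc2)cc1` gives 159000 nM
- compound 2 `COc1ccc(S(=O)(=O)n2c(-c3cn(-c4ccccc4)nc3-c3ccc(C(F)(F)F)cc3)nc3ccccc32)cc1` gives > 300000 nM as a limit

Compound 2 has only the limit > 300000 nM and no number.

Compound 3 `O=S(=O)(c1ccc(Br)cc1)n1c(-c2cn(-c3ccccc3)nc2-c2ccc(C(F)(F)F)cc2)nc2ccccc21` is unmeasured and has bromo in place of methoxy on an aromatic carbon, para to a large group (bromo in place of methoxy on an aromatic carbon). For the measured compounds named here, no measured step shows this change. Going by the values given here, the only numbered anchor is compound 1 at 159000 nM, so a moderate downward step is expected in this assay, towards less compound tolerated. The expected change is an at least 1.5-fold lower number from compound 2 to compound 3 (0.17 log units; that floor lies within the scatter), an estimate with wide uncertainty. Compound 3 is estimated at 200000 nM, within a range of 90000 nM to 400000 nM.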

Compound 3, half-maximal cytotoxic concentration: 185000 nM
For compound 3 the middle estimate is 1.1-fold (0.03 log units) above the measured one; the measured number falls inside the stated range.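

In this assay, for the compounds shown here, bromo in place of methoxy on an aromatic carbon, para to a large group, gives an at least 1.6-fold lower number from compound 2 to compound 3 (0.20 log units; that floor lies within the scatter), the first reading of this change at this position. Its full size stays unresolved, since compound 2 is recorded only as a limit: the limit of > 300000 nM in this assay, at which 1 of the 3 values shown sits. Trifluoromethyl in place of methyl on an aromatic carbon, with the bromo group held, gives a 1.2-fold higher number from compound 1 to compound 3 (0.07 log units; within the scatter), so compound 1 and compound 3 cannot be told apart here.

As far as these compounds go, an amine or a carboxylic acid in place of bromo at this position remains open. Also open, from the compounds shown here alone, is whether any group there moves the number beyond the scatter.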